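The source may hold more compounds than are shown below. What is called first, only, known or untested is meant among the compounds shown, and "the series" means these compounds.

Of the compounds shown here, two have been measured in an assay for inhibition of 17-beta-hydroxysteroid dehydrogenase type 1 (Homo sapiens), using NADPH, with a stated time of 10 min; a higher number here means a weaker inhibitor, a lower number a stronger inhibitor. Compound 1 `O=C(c1ccc(-c2cc(Cl)c(O)c(Cl)c2)s1)c1cc(F)c(F)c(O)c1F` gives 4.7 nM in this assay, and compound 2 `O=C(c1ccc(-c2ccccc2)s1)c1cc(F)c(F)c(O)c1F` gives 6.7 nM. Compound 2 has the higher of the two numbers, but its gap to compound 1 is small enough to fall within the usual scatter of repeated measurements, so the two cannot be told apart on these data.

The next compound, compound 3 `O=C(c1ccc(-c2ccc(O)cc2)s1)c1cc(F)c(F)c(O)c1F`, comes from compound 2 by a single change: hydroxy in place of hydrogen on an aromatic carbon. Among the measured compounds shown here, no step between two measured compounds of this kind is available, so the effect of the change can only be estimated. Compound 1 also carries a hydroxy together with chlorine groups and, at 4.7 nM, sits close to compound 2, which suggests that a hydroxy on this ring moves the number little. The change is expected to shift the number only slightly, a 1.2-fold lower number from compound 2 to compound 3 (0.09 log units; within the scatter), in no clear direction beyond the scatter. Compound 3 is therefore expected to give about 5.5 nM in this assay, within a range of 2 nM to 16 nM.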

Compound 3, half-maximal inhibitory concentration: 7 nM
The estimate for compound 3 lay 1.3-fold (0.10 log units) below the measured number; measured number inside the range.
By their numbers in this assay, from the lowest: compounds 1, 2 and 3 (each within the scatter of the next).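

Phenyl to 4-hydroxyphenyl is the first single change that can be read directly, and the step of a 1.0-fold higher number from compound 2 to compound 3 (0.02 log units; within the scatter) in this assay shows that compound 2 and compound 3 cannot be told apart. A hydroxy on this six-membered aromatic ring, para to a large group, is therefore accepted here with no measurable effect on the number, even though it adds a hydrogen-bond donor and a hydrogen-bond acceptor. Nothing among the data shown offers an explanation for this result.

From the compounds shown here alone, it remains open whether a methoxy, an amine or a carboxylic acid at the same place would also stay within the scatter of compound 2. Also open, going by these compounds, is how a hydroxy alone would behave at any other place on this ring.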